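Methyl to chloro on the aromatic ring of the series

The compounds below may be only part of what the source reports. "The series", "measured", "known", "first", "only" and "open" are said of these compounds alone.

The series is read in a functional assay on T47D cells (Homo sapiens) for inhibition, read by sulforhodamine B assay, with a stated time of 48 h; a lower number here means a stronger inhibitor of growth, a higher number a weaker inhibitor of growth. Three compounds have numbers. Compound 1 `COC(=O)[C@@]1(C)CCC=C2[C@@H]1CC[C@@H](C)[C@]2(C)Cc1c[nH]c2c(Br)cccc12` gives 24000 nM in this assay. Compound 2 `Cc1c(C[C@]2(C)C3=CCC[C@](C)(C(=O)O)[C@H]3CC[C@H]2C)c2cc(Cl)ccc2n1C(c1ccccc1)c1ccccc1` gives 13000 nM in this assay. Compound 3 `COC(=O)[C@@]1(C)CC[C@@H]2C3=C1CC[C@@H](C)[C@]3(C)Cc1c2[nH]c2c(C)cccc12` gives 23000 nM in this assay. For the measured compounds named here, compound 3 sits among the other two without separation: its number and that of compound 1 lie within the scatter of each other, and its number and that of compound 2 lie within the scatter as well, so no compound of the three can be set apart from the rest on these numbers.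

Compound 4 `COC(=O)[C@@]1(C)CC[C@@H]2C3=C1CC[C@@H](C)[C@]3(C)Cc1c2[nH]c2c(Cl)cccc12` has not yet been measured in this assay. It differs from compound 3 by chloro in place of methyl on an aromatic carbon. Going by the values given here, no measured pair in this set shows the effect of such an exchange, and the three measured numbers, all within scatter of one another, give no direction to read from. The step is therefore expected to be small, none beyond the scatter, and the estimated change is a 1.2-fold lower number from compound 3 to compound 4 (0.06 log units; within the scatter). For compound 4 the expected number in this assay is 20000 nM, with a range estimated from 8000 nM to 50000 nM.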

Compound 4, concentration for 50% growth inhibition: 21000 nM
Estimate against measurement, compound 4: 1.1-fold (0.02 log units) below; the measured number falls inside the stated range.
By their numbers in this assay, from the lowest: compounds 2, 4, 3 and 1 (each within the scatter of the next).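

In this assay, for the compounds shown here, chloro in place of methyl on this aromatic carbon, ortho to a fused ring and meta to a fused ring, gives a 1.1-fold lower number from compound 3 to compound 4 (0.04 log units; within the scatter); this is the first step in the set that isolates a change in one place. The earlier compounds shown here could not show this, as none of them formed a pair differing only here, whereas compound 3 and compound 4 show that this position takes either group without any separation of their numbers. Methyl and chloro each count one heavy atom, with no hydrogen-bond donors or acceptors and no net charge, and nothing measured alongside these numbers bears on why the two compounds read alike.

Left open is whether a group of another kind on the same aromatic carbon, such as an amine, a nitrile or a longer alkyl chain, would give a number beyond the scatter from compound 3. Going by these compounds alone, the reading also covers only this one exchange on the core of compound 3, so it cannot be carried to other positions on the aromatic ring or to the methyl ester.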